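Swapping Chloro for Methoxy on a Shared Core

The source may report more compounds than this note shows. Statements on the series, on what has been measured and on what is new or still open speak of the compounds shown alone.

Measured so far:
compound 1 `c1ccc(-c2nnc(-c3nsc4ccccc34)o2)cc1`: 48%
compound 2 `Clc1ccc(-c2nnc(-c3nsc4ccccc34)o2)cc1`: 33%

Both compounds were tested in a functional assay on the whole organism for inhibition, with Rattus norvegicus as the target, with a stated time of 3.5 h, at a dose of 100 mg/kg by the intraperitoneal route; a lower number here means less inhibition, a higher number more inhibition at the dose given (going by the name of the read-out). Within the data shown here, compound 2 stands lowest of the two numbers; its only neighbour is compound 1, and the one measured step, a number 15 percentage points lower from compound 1 to compound 2 (beyond the scatter), separates them.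

Compound 3 `COc1ccc(-c2nnc(-c3nsc4ccccc34)o2)cc1` differs from compound 2 by methoxy in place of chloro on an aromatic carbon. Among the measured compounds shown here, no measured step involves a methoxy group, so the single step from compound 1 to compound 2 bears on this change only loosely: it shows that exchanging the group at this place can move the inhibition by a modest amount, beyond the scatter. With nothing to tell the direction for methoxy, a modest step in either direction or none beyond the scatter is expected. Compound 3 is therefore estimated to give 40%, within a range from 20% to 60%. This estimate means an expected step of a number 7 percentage points higher from compound 2 to compound 3 (within the scatter).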

Compound 3, a percentage reported as inhibition, in the whole organism at one dose (the size of the read-out at that dose, not a potency): 33%
For compound 3 the middle estimate is 7 percentage points above the measured one, within the range that was stated.
By their numbers in this assay, from the lowest: compounds 2 and 3 (each within the scatter of the next); then compound 1.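

In this assay, the change of methoxy in place of chloro on an aromatic carbon, para to a large group, gives no change at the digits printed from compound 2 to compound 3 (within the scatter), so the two groups cannot be told apart at this place. Methoxy in place of hydrogen gives a number 15 percentage points lower from compound 1 to compound 3 (beyond the scatter), which means that the step away from compound 1 is no longer seen with chloro alone but with two different groups. Nothing available here explains why chloro and methoxy read alike.

Going by these compounds, what stays open is whether other groups at this place would also fall level with compound 2 and compound 3, or instead stay closer to compound 1. An amine, a carboxylic acid or a longer chain such as butoxy could each answer that.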